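Swapping the Aryl on the Triazole: Compound 3 to Compound 4

The source may hold more compounds than are shown below. What is called first, only, known or untested is meant among the compounds shown, and "the series" means these compounds.

Of the compounds shown here, three built on one shared core have been tested: compound 1 `N#CC1=C(N)Oc2c(c3nc4ccccc4nc3c3ccccc23)C12C(=O)N(Cc1cnnn1-c1ccccc1Cl)c1ccccc12`, compound 2 `Cc1ccc(C)c(-n2nncc2CN2C(=O)C3(C(C#N)=C(N)Oc4c3c3nc5ccccc5nc3c3ccccc43)c3ccccc32)c1` and compound 3 `N#CC1=C(N)Oc2c(N)cc3nc4ccccc4nc3c2C12C(=O)N(Cc1cnnn1-c1ccc([N+](=O)[O-])cc1)c1ccccc12`, all in an ADME assay on L02 cells (Homo sapiens) for antiproliferative activity, read by MTT assay, with a stated time of 48 h; a higher number here means a weaker inhibitor, a lower number a stronger inhibitor. For compound 1 the result is a limit, > 50000 nM. For compound 2 it is likewise a limit, > 50000 nM. For compound 3 only a limit is known, > 50000 nM. This is the limit of > 50000 nM in this assay, at which 3 of the 3 values shown sit, and the step that the two limits leave unreadable from compound 1 to compound 2 therefore cannot be sized. Compound 4 `COc1cc(-n2nncc2CN2C(=O)C3(C(C#N)=C(N)Oc4c(N)cc5nc6ccccc6nc5c43)c3ccccc32)c(OC)cc1Cl` is not yet measured; it differs from compound 3 by 4-chloro-2,5-dimethoxyphenyl in place of 4-nitrophenyl on an aromatic nitrogen. The step that the two limits leave unreadable from compound 1 to compound 2 also changes the group on that aromatic nitrogen and stays unreadable, so no movement beyond the scatter in this assay is expected. Compound 4 is expected to give 80000 nM, between 30000 nM and 300000 nM, an expected step that the limit leaves unreadable from compound 3 to compound 4.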

Compound 4, half-maximal inhibitory concentration: > 50000 nM
Compound 4: no number, only a limit (the forecaster's own chance of this, stated with the estimate: 85%); the middle value does not contradict the limit.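

Going by these compounds alone, compound 3 and compound 4 both end as limits in this assay so no step between them can be read: the limit of > 50000 nM in this assay, at which 4 of the 4 values shown sit.

The compounds shown leave open what number lies behind each limit, and whether any group on that aromatic nitrogen moves the value at all.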